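This account rests on a few compounds, and the source may have more. Where it says the series, first, only, none or still open, it means among the compounds named here.

Measured so far in an assay on COS-7 cells for inhibition of patatin-like phospholipase domain-containing protein 2 (Mus musculus), tested at 200 uM; a higher number here means more inhibition at the concentration tested (going by the name of the read-out), a lower number less inhibition:
Compound 1 `CCOC(=O)c1ccnc(-c2ccc(OCC)cc2)c1` gives 87%.
Compound 2 `CCOC(=O)c1cccc(-c2ccc(OC)cc2)c1` gives 77%.
Compound 3 `CCOC(=O)c1cccc(-c2ccsc2)c1` gives 67%.

Compound 3 has the lowest of these three numbers. Its gap to compound 2 lies within the usual scatter of such measurements, so the two cannot be ordered; its gap to compound 1 lies beyond that scatter. Compound 4 `CCOC(=O)c1cccc(-c2cccs2)c1` is the next compound to be tested. It differs from compound 3 in one place: thiophen-2-yl in place of thiophen-3-yl on an aromatic carbon. Within the data shown here, no pair of measured compounds shows this change alone, so its effect is untested here. The two groups are built from the same atoms joined differently, and the expected step of no change at the digits printed from compound 3 to compound 4 (within the scatter) is therefore small, not beyond the scatter. Compound 4 is estimated at 67%, with a range from 45% to 85%.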

Compound 4, a percentage reported as inhibition, at one concentration (the size of the read-out at that concentration, not a potency): 55%
For compound 4 the middle estimate is 12 percentage points above the measured one; measured number inside the range.
By their numbers in this assay, from the lowest: compound 4; then compounds 3, 2 and 1 (each within the scatter of the next, the first and the last beyond it).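

Swapping thiophen-3-yl for thiophen-2-yl, on an aromatic carbon meta to an ethoxycarbonyl group, is the only single change shown, and in this assay it gives a number 12 percentage points lower from compound 3 to compound 4 (beyond the scatter) as a modest drop. This position therefore responds to how the same atoms are joined, not only to which atoms are present. Nothing measured here offers a reason for this step. On these data alone, it remains open whether the swap would act alike on the core of compound 1, which carries a ring nitrogen. Also open, as far as these compounds go, is how furan-2-yl at this position, or a carboxylic acid in place of the ethoxycarbonyl group, would read.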